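Chloro removal on the aryl ring of compound 3

The source may report more compounds than this note shows. Statements on the series, on what has been measured and on what is new or still open speak of the compounds shown alone.

Compound 1 `Fc1ccc2c(c1)CCC(c1nnc(-c3cn(Cc4c(F)cccc4F)nn3)o1)O2`: 23100 nM
Compound 2 `Fc1ccc2c(c1)CCC(c1nnc(-c3cccc(Cl)c3)o1)O2`: 23100 nM
Compound 3 `Fc1ccc2c(c1)CCC(c1nnc(-c3ccccc3Cl)o1)O2`: 40800 nM

In a functional assay (on this read-out higher numbers stand for weaker inhibition and lower numbers for stronger inhibition), compound 3 gives the highest of the three numbers, but its gaps to compound 1 and to compound 2 are both within the scatter, so the three sit together as weak inhibitors. Compound 4 `Fc1ccc2c(c1)CCC(c1nnc(-c3ccccc3)o1)O2` differs from compound 3 by hydrogen in place of chloro on an aromatic carbon, ortho to a large group. Going by the values given here, the only measured step touching this ring is a 1.8-fold higher number from compound 2 to compound 3 (0.25 log units; within the scatter), itself within the scatter. Among the compounds with values here, no measured step removes a substituent from the ring, so the change has no direct anchor. Since the three numbers lie close, the expected step of a 1.0-fold lower number from compound 3 to compound 4 (0.01 log units; within the scatter) is none beyond the scatter. Compound 4 is therefore estimated at 40000 nM, with a range from 15000 nM to 120000 nM.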

Compound 4, half-maximal inhibitory concentration: 28700 nM
Compound 4: middle estimate off by 1.4-fold (0.14 log units), on the high side; measured number inside the range.
By their numbers in this assay, from the lowest: compounds 1, 2, 4 and 3 (each within the scatter of the next).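

Removing the chloro now has a direct reading in this assay: a 1.4-fold lower number from compound 3 to compound 4 (0.15 log units; within the scatter), and a 1.2-fold higher number from compound 2 to compound 4 (0.09 log units; within the scatter). Neither the 2-chlorophenyl nor the 3-chlorophenyl compound separates from the unsubstituted phenyl, so the chloro has no effect here that can be told from the scatter, at either placement. No supporting evidence bears on this result.

Going by these compounds, whether any change on this ring can move the number beyond the scatter remains open. An amine or a carboxylic acid on the phenyl ring would test that.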